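Swapping a Basic Side Chain Lowers Cytotoxicity

A few compounds are considered here, and "the series" means these few. Any claim that something is new, unique, unknown or untested is made for them only; others in the source may bear on it.

Compound 1, `Cc1cc(/C=C/C#N)cc(C)c1Oc1nc(Nc2ccc(N3CCCC(NS(N)(=O)=O)C3)cc2)nc2ccsc12`, gives only a limit in an ADME assay on MT4 cells (Homo sapiens) for cytotoxicity, read by MTT assay, with a stated time of 5 days; on this read-out lower numbers stand for higher toxicity in this test and higher numbers for lower toxicity in this test: > 217000 nM.
Compound 2, `Cc1cc(/C=C/C#N)cc(C)c1Oc1nc(Nc2ccc(CN3CCNCC3)cc2)nc2ccsc12`, gives 3970 nM in this assay.
Compound 3, `Cc1cc(/C=C/C#N)cc(C)c1Oc1nc(Nc2ccc(CN3CCNCC3)cc2)nc2sccc12`, gives 4030 nM in this assay.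

Compounds 2 and 3 are built from the same atoms joined differently; the difference between the two cores is not broken down here. In this assay the two give numbers that lie within the usual scatter of each other, so nothing separates them. The value recorded for compound 1 is a limit of the assay rather than a number, (the limit of > 217000 nM in this assay, at which 1 of the 3 values shown sits). The change that leads from compound 2 to compound 1 is 3-(sulfamoylamino)piperidin-1-yl in place of (piperazin-1-yl)methyl on an aromatic carbon, and the step it produced is an at least 54-fold higher number from compound 2 to compound 1 (1.73 log units; beyond the scatter), a large move toward lower toxicity.

Compound 4, `Cc1cc(/C=C/C#N)cc(C)c1Oc1nc(Nc2ccc(N3CCCC(NS(N)(=O)=O)C3)cc2)nc2sccc12`, has not yet been measured in this assay. It differs from compound 3 by 3-(sulfamoylamino)piperidin-1-yl in place of (piperazin-1-yl)methyl on an aromatic carbon, the same change at the same place as the one already seen, occurring twice in all among these compounds. Because an at least 54-fold higher number from compound 2 to compound 1 (1.73 log units; beyond the scatter) was a large and clear step, compound 4 is expected to show a step of similar size, a 62-fold higher number from compound 3 to compound 4 (1.79 log units; beyond the scatter). Compound 4 is thus estimated at about 250000 nM in this assay, most likely between 60000 nM and 700000 nM, and quite possibly reported only as a limit again.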

Compound 4, half-maximal cytotoxic concentration: > 217000 nM
Compound 4 gave a limit, no number; the forecaster's own chance of this, stated with the estimate: 70%; the middle value is on the limit's open side.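

On the second core the swap again gives a large move toward lower toxicity in this assay, with an at least 53-fold higher number from compound 3 to compound 4 (1.73 log units; beyond the scatter). Placing 3-(sulfamoylamino)piperidin-1-yl where (piperazin-1-yl)methyl stood therefore moves the number in the same direction on both cores shown, and in this small set the result carries from one core to the other: the same change on two cores in this assay, an at least 54-fold higher number (1.73 log units; beyond the scatter) from compound 2 to compound 1 and an at least 53-fold higher number (1.73 log units; beyond the scatter) from compound 3 to compound 4; the limit leaves it open whether they differ. What this does not show is the true size of either step, or whether the two cores respond equally, since compound 1 and compound 4 both give only a limit rather than a number: the limit of > 217000 nM in this assay, at which 2 of the 4 values shown sit.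

The compounds shown leave open which part of the swap matters, as the entering group differs from the leaving one in its ring, in its point of attachment to the aromatic ring and in carrying the sulfamoylamino group, and a plain piperidin-1-yl or a piperidine bearing a simple amine would help to separate these parts. Also open, going by these compounds, is whether the same swap would behave this way on a core in which the nitrile gives way to another group, such as an amide or a carboxylic acid.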